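The source may hold more compounds than are shown below. What is called first, only, known or untested is meant among the compounds shown, and "the series" means these compounds.

Compound 1, `C=C(C)[C@@H]1CC=C(Cn2cc(COc3cc(C4NC(=O)NC(C)=C4C(=O)OCC)ccc3OC)nn2)CC1`: > 100000 nM
Compound 2, `C=C(C)[C@@H]1CC=C(Cn2cc(COc3ccc(C4NC(=O)NC(C)=C4C(=O)OCC)cc3OC)nn2)CC1`: > 100000 nM
Compound 3, `C=C(C)[C@@H]1CC=C(Cn2cc(COc3cccc(C4NC(=O)NC(C)=C4C(C)=O)c3)nn2)CC1`: > 100000 nM

These three compounds share a core and were tested in a functional assay on NCI-H460 cells (Homo sapiens) for inhibition, read by sulforhodamine B assay, with a stated time of 48 h; a lower number here means a stronger inhibitor of growth, a higher number a weaker inhibitor of growth. For compound 2 the result is only a limit of the assay, not a measured number. Within the data shown here, the same is true of compound 1 and of compound 3, so that (the limit of > 100000 nM in this assay, at which 3 of the 3 values shown sit), and no compound among the three gives a real figure to compare against. Compound 2 therefore stands nowhere in particular: it sits at the same limit as everything else shown.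

Compound 4, `C=C(C)[C@@H]1CC=C(Cn2cc(COc3ccc(C4NC(=O)NC(C)=C4C(C)=O)cc3OC)nn2)CC1`, is compound 2 with one change: methyl in place of ethoxy on a carbonyl carbon. Compound 3 also carries an acetyl group in place of the ester, and its value is likewise only a limit. Among the measured compounds shown here, no measured step exists for this change, so the expectation rests only on the fact that every value shown sits at the limit.

The step from compound 2 to compound 4 is expected to be none beyond the scatter, that is a step that the limit leaves unreadable from compound 2 to compound 4. Compound 4 is expected to give 150000 nM, most likely again as a limit, with a range from 50000 nM to 500000 nM.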

Compound 4, concentration for total growth inhibition: > 100000 nM
Compound 4: no number, only a limit (the forecaster's own chance of this, stated with the estimate: 85%); the middle value is on the limit's open side.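

Compound 2 and compound 4 both sit at the limit of the assay rather than at a measured number, so no step can be read for the change from ethoxycarbonyl to acetyl: the limit of > 100000 nM in this assay, at which 4 of the 4 values shown sit.

The compounds shown leave open whether either group, or any change to the shared core, gives a measurable inhibition of growth.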